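Swapping the methoxyphenyl for a chloro-fluorophenyl group

A few compounds are considered here, and "the series" means these few. Any claim that something is new, unique, unknown or untested is made for them only; others in the source may bear on it.

Compound 1, `COc1ccc(-c2nc3ccccc3n2CCCN2CCC(c3cccc(NC(C)=O)c3)CC2)cc1`: 9 nM
Compound 2, `CC(=O)Nc1cccc(C2CCN(CCCn3c(-c4ccc(C#N)cc4)nc4ccccc43)CC2)c1`: 16 nM
Compound 3, `CC(=O)Nc1cccc(C2CCN(CCCn3c(-c4ccc(Cl)cc4Cl)nc4ccccc43)CC2)c1`: 3 nM

All three were tested in an assay for displacement of a labelled ligand from melanin-concentrating hormone receptor 1 (Homo sapiens), read by fluorescence; a lower number here means a stronger inhibitor, a higher number a weaker inhibitor. Compound 1 holds the second highest of the three numbers; its nearest neighbour is compound 2 (a 1.8-fold higher number from compound 1 to compound 2 (0.25 log units; within the scatter)) and the furthest is compound 3 (a 3.0-fold lower number from compound 1 to compound 3 (0.48 log units; beyond the scatter)). Compound 4, `CC(=O)Nc1cccc(C2CCN(CCCn3c(-c4ccc(F)cc4Cl)nc4ccccc43)CC2)c1`, has not been measured. It differs from compound 1 in one place: 2-chloro-4-fluorophenyl in place of 4-methoxyphenyl on an aromatic carbon. The step that bears most on it is a 3.0-fold lower number from compound 1 to compound 3 (0.48 log units; beyond the scatter), and a 5.3-fold lower number from compound 2 to compound 3 (0.73 log units; beyond the scatter) points the same way. Compound 4 carries 2-chloro-4-fluorophenyl rather than 2,4-dichlorophenyl, so a somewhat smaller step downward is expected. The estimate for compound 4 is 5 nM, ranging from 2 nM to 12 nM, an expected step of a 1.8-fold lower number from compound 1 to compound 4 (0.26 log units; within the scatter).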

Compound 4, half-maximal inhibitory concentration: 4 nM
For compound 4 the middle estimate is 1.3-fold (0.10 log units) above the measured one; the measured number falls inside the stated range.
By their numbers in this assay, from the lowest: compounds 3 and 4 (each within the scatter of the next); then compounds 1 and 2 (each within the scatter of the next).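

In this assay, the 2-chloro-4-fluorophenyl group keeps the advantage first seen with 2,4-dichlorophenyl, giving a 2.3-fold lower number from compound 1 to compound 4 (0.35 log units; beyond the scatter) and a 4.0-fold lower number from compound 2 to compound 4 (0.60 log units; beyond the scatter). Fluoro in place of chloro gives a 1.3-fold higher number from compound 3 to compound 4 (0.12 log units; within the scatter), so the two halogen-bearing rings cannot be told apart here, and this position tolerates that swap. Nothing available explains why these rings give lower numbers than 4-methoxyphenyl or 4-cyanophenyl. Still open, as far as these compounds go, is whether a phenyl ring carrying a single chloro, or one carrying an amine or a carboxylic acid, would hold these numbers.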